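From Methyl to Chloro on a Weakly Cytotoxic Compound

A few compounds are considered here, and "the series" means these few. Any claim that something is new, unique, unknown or untested is made for them only; others in the source may bear on it.

- compound 1 `Cc1ccc(S(=O)(=O)N2C(=O)NCC2c2ccccc2)cc1`: > 316000 nM
- compound 2 `Cc1ccc(S(=O)(=O)N2C(=O)NCC2c2ccc(Br)cc2)cc1`: 80000 nM

In a functional assay on SK-MEL-2 cells (Homo sapiens) for cytotoxicity (a higher number here means a weaker inhibitor, a lower number a stronger inhibitor), compound 1 gives > 316000 nM, which is a limit and not a number. Going by the values given here, compound 2 gives 80000 nM, the only exact number so far. Compound 3 `O=C1NCC(c2ccc(Br)cc2)N1S(=O)(=O)c1ccc(Cl)cc1` carries chloro in place of methyl on an aromatic carbon. Among the compounds with values here, the one measured step, an at least 3.9-fold lower number from compound 1 to compound 2 (0.59 log units; beyond the scatter), swapped bromo for hydrogen elsewhere, so it is only a loose guide to this change. No step beyond the scatter is therefore expected in this assay, in either direction. The expected change is a 1.1-fold lower number from compound 2 to compound 3 (0.06 log units; within the scatter). Compound 3 is estimated at 70000 nM, with an expected range of 25000 nM to 200000 nM.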

Compound 3, half-maximal inhibitory concentration: 106000 nM
Compound 3: the middle estimate sits 1.5-fold (0.18 log units) below what was measured, within the range that was stated.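

In this assay, chloro in place of methyl, para to a large group, gives a 1.3-fold higher number from compound 2 to compound 3 (0.12 log units; within the scatter). So this swap, made in a different place from the earlier bromo change, leaves compound 2 and compound 3 indistinguishable in this measurement. Compound 1 remains a limit and not a number: the limit of > 316000 nM in this assay, at which 1 of the 3 values shown sits.

Going by these compounds, whether an amine, a carboxylic acid or a longer chain at this position would shift the number beyond the scatter stays open. On these data alone, whether chloro behaves the same way on the core of compound 1, without the bromo, also stays open.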